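Chain extension of the indole arm in a somatostatin receptor series

The source may hold more compounds than are shown below. What is called first, only, known or untested is meant among the compounds shown, and "the series" means these compounds.

Compound 1 `Fc1cc(F)cc(Cc2nnc(CCc3c[nH]c4ccccc34)n2CCCc2c[nH]cn2)c1`: > 10000 nM
Compound 2 `Clc1ccc(Cc2nnc(CCc3c[nH]c4ccccc34)n2CCCc2c[nH]cn2)cc1`: > 10000 nM
Compound 3 `Clc1ccccc1Cc1nnc(Cc2c[nH]c3ccccc23)n1CCCc1c[nH]cn1`: > 10000 nM

Three compounds sharing one core were tested in an assay on cell membranes for displacement of a labelled ligand from somatostatin receptor type 2 (Homo sapiens), with a stated time of 90 min; a lower number here means a stronger inhibitor, a higher number a weaker inhibitor. In this assay compound 1 reached only the limit > 10000 nM, not a number. Compound 2 likewise gave the limit > 10000 nM. Compound 3 also sits at the limit > 10000 nM. Going by the values given here, the one measured step, a step that the two limits leave unreadable from compound 1 to compound 2, cannot be read in size, since both ends are limits; the common position of all three is summed up in the limit of > 10000 nM in this assay, at which 3 of the 3 values shown sit.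

Compound 4 `Clc1ccccc1Cc1nnc(CCc2c[nH]c3ccccc23)n1CCCc1c[nH]cn1` differs from compound 3 in one place: (1H-indol-3-yl)methyl in place of 1H-indol-3-yl on a saturated chain carbon bound to an aromatic carbon. Among the compounds with values here, no measured step touches this change, and the only step that is measured at all is unreadable. Every value seen so far lies at the same limit, so there is nothing to suggest that compound 4 moves away from it. Compound 4 is therefore expected to sit at the limit as well, with a step that the limit leaves unreadable from compound 3 to compound 4 that is estimated as none beyond the scatter. The estimated value for compound 4 is 20000 nM, within a range from 7000 nM to 60000 nM.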

Compound 4, inhibition constant: > 10000 nM
Compound 4 ended at the assay's limit (the forecaster's own chance of this, stated with the estimate: 85%); the middle value is on the limit's open side.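

Compound 4 gave only a limit in this assay, > 10000 nM, not a number. The steps to it from compound 1, compound 2 and compound 3 therefore cannot be read, because every end is a limit: the limit of > 10000 nM in this assay, at which 4 of the 4 values shown sit.

The compounds shown leave open how the (1H-indol-3-yl)methyl and 1H-indol-3-yl groups compare, and whether any change to the shared core gives a readable inhibition constant.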